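Fluoro on the Chromone Core of Two Thiocarbonyl Series

A few compounds are considered here, and "the series" means these few. Any claim that something is new, unique, unknown or untested is made for them only; others in the source may bear on it.

Compound 1 `O=c1c(C2N=C(c3ccccc3)SS2)coc2cc(Cl)ccc12` and compound 2 `O=c1c(C(=S)Nc2ccccc2)coc2ccccc12` carry different groups on related cores; how the two cores differ is not broken down here. In a functional assay on COLO 205 cells (Homo sapiens) for inhibition, read by sulforhodamine B assay, with a stated time of 48 h (a higher number here means a weaker inhibitor, a lower number a stronger inhibitor), compound 1 gives 76700 nM, and compound 2 gives 72600 nM, the two lying within the scatter of each other. Compound 3 `O=c1c(C(=S)Nc2ccccc2)coc2ccc(F)cc12` differs from compound 2 by fluoro in place of hydrogen on an aromatic carbon. For compound 3 this assay reports only a limit, > 100000 nM, so the step is known only as a floor: an at least 1.3-fold higher number from compound 2 to compound 3 (0.13 log units; that floor lies within the scatter), resting on (the limit of > 100000 nM in this assay, at which 1 of the 3 values shown sits).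

Compound 4 `O=c1c(C2N=C(c3ccccc3)SS2)coc2cc(Cl)c(F)cc12` has not yet been measured; it differs from compound 1 by fluoro in place of hydrogen on an aromatic carbon. This is the same kind of change as that from compound 2 to compound 3, though not the same, since in compound 4 the fluoro enters ortho to a chloro group, which the place in compound 3 lacks. Beside the earlier step, a step of about the same size, a 1.2-fold higher number from compound 1 to compound 4 (0.09 log units; within the scatter), is expected, because the only measured example of this change, an at least 1.3-fold higher number from compound 2 to compound 3 (0.13 log units; that floor lies within the scatter), gave a floor within the scatter. Compound 4 is therefore estimated at 95000 nM in this assay, between 50000 nM and 200000 nM, with a real chance that only a limit is reported.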

Compound 4, half-maximal inhibitory concentration: > 100000 nM
Compound 4 ended at the assay's limit (the forecaster's own chance of this, stated with the estimate: 45%); at least 1.0-fold (0.02 log units) between middle value and limit.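

In this assay compound 4 gives > 100000 nM, which is a limit of the assay and not a number. The new step is therefore known only as a floor, an at least 1.3-fold higher number from compound 1 to compound 4 (0.11 log units; that floor lies within the scatter), and it shows that fluoro in place of hydrogen on an aromatic carbon left a compound at the assay's limit on both cores, but not how large the change is on either core. It also cannot show whether the chloro group in compound 4, ortho to the entering fluoro, alters the outcome, and the comparison of the two cores reaches only this far: the same change on two cores in this assay, an at least 1.3-fold higher number (0.13 log units; that floor lies within the scatter) from compound 2 to compound 3 and an at least 1.3-fold higher number (0.11 log units; that floor lies within the scatter) from compound 1 to compound 4; the limit leaves it open whether they differ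

The compounds shown leave open how a methoxy group or an amine at the same place on the core of compound 1 would read in this assay. They also leave open whether a chloro or methoxy group on the phenyl ring of either series would bring the fluoro compounds to a measurable value.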